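The source may report more compounds than this note shows. Statements on the series, on what has been measured and on what is new or still open speak of the compounds shown alone.

In a physicochemical assay, with a stated time of 6 min (a lower number here means a stronger inhibitor, a higher number a weaker inhibitor), compound 1 (`O=C(Nc1ccc(Br)cc1)Nc1nc(-c2cc3ccccc3o2)cs1`) gives > 200000 nM, which is a limit of the assay and not a number. For the measured compounds named here, compound 2 (`O=C(Nc1ccccc1)Nc1nc(-c2cc3cc([N+](=O)[O-])ccc3o2)cs1`) gives 183000 nM, and this is the only exact number available so far. Compound 3 (`COc1cccc(NC(=O)Nc2nc(-c3cc4ccccc4o3)cs2)c1`) has not yet been measured. It keeps the core of compound 1 and changes one group, with 3-methoxyphenyl in place of 4-bromophenyl on an amide-type nitrogen. Going by the values given here, no pair of measured compounds shows what a change of this kind does, so the expectation has little to rest on. With compound 2 at 183000 nM, a weak inhibitor seems likely again. The expected step of an at least 1.1-fold lower number from compound 1 to compound 3 (0.07 log units; that floor lies within the scatter) is no larger than the usual scatter, in either direction. The estimate for compound 3 is 170000 nM, with an expected range from 60000 nM to 400000 nM.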

Compound 3, half-maximal inhibitory concentration: 200 nM
Compound 3: middle estimate off by 850-fold (2.93 log units), on the high side; measured number outside the range, below it.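

In this assay, putting 3-methoxyphenyl in place of 4-bromophenyl on the amide-type nitrogen gives an at least 1000-fold lower number from compound 1 to compound 3 (3.00 log units; beyond the scatter), which shows that this one position can separate a very weak inhibitor from a strong one while the rest of the molecule stays the same. For the compounds shown here, no earlier pair of compounds differing in one place could show this. Because compound 1 sits at a limit of the assay and not at an exact number, the true size of the step is unknown and the printed figure is only a floor: the limit of > 200000 nM in this assay, at which 1 of the 3 values shown sits.

Going by these compounds, the two groups differ both in the substituent and in its numbered place on the phenyl ring, so it remains open which of these matters. On these data alone, it is also open how an amine, a carboxylic acid or a longer alkoxy chain would behave in place of the methoxy group.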